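The compounds below may be only part of what the source reports. "The series", "measured", "known", "first", "only" and "open" are said of these compounds alone.

Compound 1, `O=C(CCc1cccc2c1B(O)OC2)Nc1ccc(F)cc1`, gives 12000 nM.
Compound 2, `O=C(CCc1cccc2c1B(O)OC2)Nc1cccc(-c2cccc(Cl)c2)c1`, gives 58000 nM.
Compound 3, `O=C(CCc1cccc2c1B(O)OC2)Nc1cccc(-c2cccc(OC(F)(F)F)c2)c1`, gives 9800 nM.

These three numbers come from an ADME assay on WI-38 cells (Homo sapiens) for cytotoxicity, read by MTT assay, with a stated time of 72 h; a higher number here means a weaker inhibitor, a lower number a stronger inhibitor. Among them compound 2 stands highest: compound 1 sits lower by a gap beyond the usual scatter, and compound 3 sits lowest of the three. Among the measured compounds shown here, the one single-point step that the data hold runs a 5.9-fold lower number from compound 2 to compound 3 (0.77 log units; beyond the scatter).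

Compound 4, `N#Cc1ccc(-c2cccc(NC(=O)CCc3cccc4c3B(O)OC4)c2)cc1`, differs from compound 2 in this way: 4-cyanophenyl in place of 3-chlorophenyl on an aromatic carbon. The change sits in the same part of the molecule as the step from compound 2 to compound 3, where swapping one group on the outer ring for another gave a modest move toward a lower number in this assay. That step is the only one that bears on the present change, and the new group is not the same as the one tried there, so its direction is a guide rather than a rule. A lower number than compound 2 is therefore expected, modest in size, with the outcome for compound 4 estimated at 15000 nM and a range of 5000 nM to 45000 nM. The expected step is a 3.9-fold lower number from compound 2 to compound 4 (0.59 log units; beyond the scatter).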

Compound 4, half-maximal inhibitory concentration: 12000 nM
Compound 4: the middle estimate sits 1.3-fold (0.10 log units) above what was measured; the range from low to high includes it.
By their numbers in this assay, from the lowest: compounds 3, 1 and 4 (each within the scatter of the next); then compound 2.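

In this assay, the step of a 4.8-fold lower number from compound 2 to compound 4 (0.68 log units; beyond the scatter) gives this position a second replacement for the 3-chlorophenyl group that lowers the number, so the move seen with compound 3 is no longer a single case. The two replacements share little beyond the outer ring itself, yet compound 3 at 9800 nM and compound 4 at 12000 nM lie within the usual scatter of each other, so on these values the 3-chlorophenyl group of compound 2 is the one that stands apart. This change also swaps the substituent and shifts where it sits on the outer ring, and nothing available here explains the size or direction of the step.

A 4-chlorophenyl or a 3-cyanophenyl group at this place would help show how much of the step belongs to the substituent and how much to its position on the outer ring. Also open, from the compounds shown here alone, is whether an amine or a carboxylic acid on that ring would lower the number in the same way, or would leave it where compound 2 stands.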